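Amide side-chain variation in the shared core series

The source may report more compounds than this note shows. Statements on the series, on what has been measured and on what is new or still open speak of the compounds shown alone.

Measured so far:
- compound 1, `C=CC1=C(C(=O)NCCCCC)C(c2ccc(OC)cc2)OC1`: in a functional assay on A549 cells (Homo sapiens) for cytotoxicity, read by MTT assay, with a stated time of 24 h (on this read-out higher numbers stand for weaker inhibition and lower numbers for stronger inhibition), compound 1 gives 36500 nM.
- compound 2, `C=CC1=C(C(=O)Nc2ccccc2)C(c2ccc(Cl)c(Cl)c2)OC1`: compound 2 reaches only a limit of the assay in this assay, > 100000 nM.
- compound 3, `C=CC1=C(C(=O)NCCC)C(c2ccc(OC)c(OC)c2)OC1`: compound 3 likewise gives only a limit in this assay, > 100000 nM.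

Compound 1 thus stands as the only numbered result in the set; the other two values sit at the limit of > 100000 nM in this assay, at which 2 of the 3 values shown sit. Among the compounds with values here, no step between measured compounds is available to guide the next move.

Compound 4, `C=CC1=C(C(=O)NCc2ccc(C)cc2)C(c2ccc(OC)cc2)OC1`, differs from compound 1 in one place: 4-methylphenyl in place of butyl on a saturated chain carbon bound to an amide-type nitrogen. Within the data shown here, with no comparable step measured, the step of a 1.2-fold lower number from compound 1 to compound 4 (0.09 log units; within the scatter) is expected to be small, within the usual scatter. Compound 4 is estimated to give 30000 nM, in the range 8000 nM to 120000 nM.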

Compound 4, half-maximal inhibitory concentration: > 100000 nM
Compound 4 was reported as a limit (the forecaster's own chance of this, stated with the estimate: 30%); at least 3.3-fold (0.52 log units) between middle value and limit.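

In this assay, within the data shown here, 4-methylphenyl in place of butyl on a saturated chain carbon bound to an amide-type nitrogen gives an at least 2.7-fold higher number from compound 1 to compound 4 (0.43 log units; beyond the scatter), the first step that can be read. Compound 4 gives > 100000 nM, which is a limit of the assay. The side chain of compound 1 thus remains the only one here with a numbered result: the limit of > 100000 nM in this assay, at which 3 of the 4 values shown sit.

On these data alone, the full size of the step stays open, since one end of it is a limit. Also open, as far as these compounds go, is whether a longer chain such as hexyl, or a terminal amine on the amide side chain, would give a numbered result.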